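The source may hold more compounds than are shown below. What is called first, only, known or untested is meant among the compounds shown, and "the series" means these compounds.

Compound 1 `COc1ccc(Cn2nc(-c3ccccc3)c3cc(C(=N)Nc4ccccc4)nc(NC4CCCCC4)c32)cc1` is the starting point of this account. In an ADME assay on AG1523 cells (Homo sapiens) for cytotoxicity, read by MTT assay, with a stated time of 72 h (on this read-out higher numbers stand for weaker inhibition and lower numbers for stronger inhibition), compound 1 gives 26800 nM, the highest of the two numbers available, with its nearest neighbour being compound 2 `N=C(Nc1ccccc1)c1cc2c(-c3ccccc3)n[nH]c2c(NC2CCCCC2)n1`, which in this assay gives 4190 nM. Among the measured compounds shown here, the only single-point step in the set runs between these two: a 6.4-fold lower number from compound 1 to compound 2 (0.81 log units; beyond the scatter). A third compound, compound 3 `CN1CCN(c2ccc(NC(=N)c3cc4cn[nH]c4cn3)cc2)CC1`, was put into this assay but returned "not determined" (no result reported), so it contributes no number.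

The compound now in question is compound 4 `COc1ccc(Cn2nc(-c3ccccc3)c3cc(C(=N)Nc4ccc(N5CCN(C)CC5)cc4)nc(NC4CCCCC4)c32)cc1`. It differs from compound 1 as follows: 4-methylpiperazin-1-yl in place of hydrogen on an aromatic carbon. For the measured compounds named here, no measured step touches this change: the step from compound 1 to compound 2 concerns the aromatic nitrogen, not the carbon in question, and compound 3, which carries a 4-methylpiperazin-1-yl group, has no number. Nothing in the data therefore points to a change in either direction, and the expectation for compound 4 is a step of no more than the scatter, a 1.1-fold lower number from compound 1 to compound 4 (0.03 log units; within the scatter). Compound 4 is accordingly estimated at 25000 nM, within a range of 10000 nM to 60000 nM.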

Compound 4, half-maximal inhibitory concentration: 3330 nM
Compound 4: the middle estimate sits 7.5-fold (0.88 log units) above what was measured; measured number outside the range, below it.
By their numbers in this assay, from the lowest: compounds 4 and 2 (each within the scatter of the next); then compound 1.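

With 4-methylpiperazin-1-yl in place of hydrogen, this assay gives an 8.0-fold lower number from compound 1 to compound 4 (0.91 log units; beyond the scatter), which shows that the number responds to substitution at this aromatic carbon, para to a large group. Among the compounds shown here, until now the only readable change lay on the aromatic nitrogen, with a 6.4-fold lower number from compound 1 to compound 2 (0.81 log units; beyond the scatter), so two single changes at separate places on compound 1 are now known, and both lower the number beyond the scatter. Nothing at hand explains why the number falls with this change.

As far as these compounds go, it remains open whether a smaller amine such as dimethylamino, a morpholine ring or a carboxylic acid at this carbon would give a step of similar size or direction. From the compounds shown here alone, it is also open whether 4-methylpiperazin-1-yl would lower the number on compound 2, which lacks the 4-methoxybenzyl group.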